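Cyclopropyl for Ethyl on the Shared Core

A few compounds are considered here, and "the series" means these few. Any claim that something is new, unique, unknown or untested is made for them only; others in the source may bear on it.

Three compounds were measured in a functional assay on Jurkat cells (Homo sapiens) for inhibition; a lower number here means a stronger inhibitor, a higher number a weaker inhibitor. Compound 1 `CCOC(=O)c1cnc(NN2C(=O)CCC2=O)nc1C(F)(F)F` gives 1600 nM. Compound 2 `CCOC(=O)c1cnc(N(Cc2ccccc2)N2C(=O)C=C(C)C2=O)nc1C(F)(F)F` gives 450 nM. Compound 3 `CCOC(=O)c1cnc(NN2C(=O)C=C(C)C2=O)nc1CC` gives 400 nM. Among these three numbers compound 3 stands at the low end, yet its gap to compound 2 lies within the usual scatter of repeated measurements, so the two cannot be set in order; only its gap to compound 1 lies beyond the scatter, with compound 1 giving the higher number.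

Compound 4 `CCOC(=O)c1cnc(NN2C(=O)C=C(C)C2=O)nc1C1CC1` has not been measured in this assay. It differs from compound 3 in one place, (cyclopropyl in place of ethyl on an aromatic carbon).

Within the data shown here, no measured pair in this set shows what this exchange does, and the structures of compounds 1 and 2 differ from compound 3 elsewhere, so they give no guidance on it. With nothing measured to point in either direction, the expected step of a 1.1-fold lower number from compound 3 to compound 4 (0.06 log units; within the scatter) is a small one, within or near the scatter, with no strong lean toward a higher or a lower number.

On that basis compound 4 is expected to give 350 nM in this assay, within a range from 150 nM to 900 nM.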

Compound 4, half-maximal inhibitory concentration: 1500 nM
Estimate against measurement, compound 4: 4.3-fold (0.63 log units) below; measured number above the stated range.
By their numbers in this assay, from the lowest: compounds 3 and 2 (each within the scatter of the next); then compounds 4 and 1 (each within the scatter of the next).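

In this assay, among these compounds, the first one-place comparison in this set shows that the aromatic carbon ortho to an ethoxycarbonyl group is sensitive to what it carries: cyclopropyl in place of ethyl gives a 3.8-fold higher number from compound 3 to compound 4 (0.57 log units; beyond the scatter), a move toward weaker inhibition. Among the compounds shown here, the exchange is a small one on paper, with 3 heavy atoms entering where 2 leave, no hydrogen-bond donors or acceptors on either side and no net charge, yet of these two groups ethyl is clearly the better one here, a difference the earlier compounds could not reveal. Nothing among the available data accounts for this loss, so the step stands as an observation without an explanation.

Going by these compounds, what stays open is whether the loss follows from the three-membered ring itself or from the added carbon, which an open-chain propyl or an isopropyl group at this position would help to separate. A methyl group or a plain hydrogen on the same carbon would also show whether ethyl is near the best choice here or merely better than cyclopropyl.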